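The compounds below may be only part of what the source reports. "The series", "measured", "known", "first", "only" and "open" are said of these compounds alone.

Working notes on the series

Two cores are in play. Compound 1 `Cc1ccccc1NNC(=O)c1ccc(NS(=O)(=O)c2cnc(O)nc2O)cc1` and compound 2 `Cc1cccc(NNC(=O)c2ccc(NS(=O)(=O)c3cnc(O)nc3O)cc2)c1` share the first; compound 3 `Cc1ccccc1NNC(=O)c1ccccc1NS(=O)(=O)c1cnc(O)nc1O` and compound 4 `Cc1cccc(NNC(=O)c2ccccc2NS(=O)(=O)c2cnc(O)nc2O)c1` share the second. The difference between the core of compound 1 and the core of compound 3 is not broken down here.

In a functional assay on A549 cells (Homo sapiens) for antiproliferative activity, read by MTT assay, with a stated time of 24 h (on this read-out lower numbers stand for stronger inhibition and higher numbers for weaker inhibition), compound 1 gives 14500 nM. Compound 2 reaches only the limit of this assay and is recorded as > 20000 nM. The step of an at least 1.3-fold higher number from compound 1 to compound 2 (0.13 log units; that floor lies within the scatter) goes with the change (3-methylphenyl in place of 2-methylphenyl on an amine nitrogen). Compound 3 also reaches only the limit of this assay and is recorded as > 20000 nM.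

Compound 4 has not been measured in this assay. It differs from compound 3 by 3-methylphenyl in place of 2-methylphenyl on an amine nitrogen, and the place of the change is described in the same words as for the pair of compound 1 and compound 2, so this is the same change carried onto the second core. Within the data shown here, the earlier step of an at least 1.3-fold higher number from compound 1 to compound 2 (0.13 log units; that floor lies within the scatter) gives the only guide to its size, and that step could not be resolved because the limit of > 20000 nM in this assay, at which 2 of the 3 values shown sit, caps what the assay reports.

Compound 3 already sits at that limit, so the expected step that the limit leaves unreadable from compound 3 to compound 4 is expected to be small and most likely again unresolved. Compound 4 is therefore expected to give about 30000 nM in this assay, with a range from 15000 nM to 60000 nM, and a further limit rather than a number is the likely outcome.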

Compound 4, half-maximal inhibitory concentration: > 20000 nM
Compound 4 was reported as a limit (the forecaster's own chance of this, stated with the estimate: 85%); the middle value is on the limit's open side.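

Compound 3 and compound 4 are both recorded only as limits in this assay, so no step between them can be read: the limit of > 20000 nM in this assay, at which 3 of the 4 values shown sit.

The compounds shown leave open whether 3-methylphenyl in place of 2-methylphenyl on an amine nitrogen changes the read-out on either core, and how the core of compound 1 compares with the core of compound 3.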